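Swapping chloro for bromo on two related cores

The source may hold more compounds than are shown below. What is called first, only, known or untested is meant among the compounds shown, and "the series" means these compounds.

Of the compounds shown here, three have so far been tested in a functional assay on MDA-MB-468 cells (Homo sapiens) for cytotoxicity, read by sulforhodamine B assay, with a stated time of 48 h; a lower number here means a stronger inhibitor of growth, a higher number a weaker inhibitor of growth. Compound 1, `NC(=S)N/N=C1/C(=O)N(CN2CCN(c3ccnc4cc(C(F)(F)F)ccc34)CC2)c2cc(Cl)ccc21`, gives 11000 nM. Compound 2, `NC(=S)N/N=C1/C(=O)N(CN2CCN(c3ccnc4cc(C(F)(F)F)ccc34)CC2)c2cc(Br)ccc21`, gives 39600 nM. Compound 3, `NC(=S)N/N=C1\C(=O)Nc2cccc(Cl)c21`, gives 24000 nM. How the core of compound 3 differs from the core of compound 1 is not broken down here.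

Compound 1 and compound 2 differ in one place only: bromo in place of chloro on an aromatic carbon. That single change gave a 3.6-fold higher number from compound 1 to compound 2 (0.56 log units; beyond the scatter).

Compound 4, `NC(=S)N/N=C1\C(=O)Nc2cccc(Br)c21`, has not yet been measured. It differs from compound 3 by bromo in place of chloro on an aromatic carbon. Among the measured compounds shown here, this is the same kind of change as the one from compound 1 to compound 2, but not the same: in compound 4 the bromo sits ortho to a fused ring and meta to a fused ring, whereas in compound 2 it sits meta to a fused ring and para to a fused ring.

The expectation for compound 4 rests on the earlier pair, whose step was a 3.6-fold higher number from compound 1 to compound 2 (0.56 log units; beyond the scatter). On that basis compound 4 is expected to show a 2.5-fold higher number from compound 3 to compound 4 (0.40 log units; beyond the scatter). Compound 4 is therefore estimated at 60000 nM, with a likely range from 20000 nM to 150000 nM.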

Compound 4, concentration for 50% growth inhibition: 21200 nM
For compound 4 the middle estimate is 2.8-fold (0.45 log units) above the measured one; measured number inside the range.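

Bromo in place of chloro on an aromatic carbon gave a 1.1-fold lower number from compound 3 to compound 4 (0.05 log units; within the scatter), so in this assay the two compounds cannot be told apart. The size of this swap on one core therefore did not carry over to the other, and the step seen on the core of compound 1 cannot simply be added to a related core in this series: the same change on two cores in this assay, a 3.6-fold higher number (0.56 log units; beyond the scatter) from compound 1 to compound 2 and a 1.1-fold lower number (0.05 log units; within the scatter) from compound 3 to compound 4, 4.1-fold (0.61 log units) apart, beyond the scatter of two such steps This does not show why the steps differ, since the two pairs differ both in the core and in where the halogen sits, and two pairs cannot separate these.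

The compounds shown leave open whether a group other than these two halogens, such as fluoro, methyl or an amine, would change the number at this same carbon on the core of compound 3. They also leave open whether chloro and bromo would stay within the scatter on that core with the halogen placed as in compound 1 and compound 2.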